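Sulfonyl Aryl Swap Where Only Assay Limits Are Known

This account rests on a few compounds, and the source may have more. Where it says the series, first, only, none or still open, it means among the compounds named here.

Three compounds sharing a core have been examined in a functional assay on HepG2 cells (Homo sapiens) for antiproliferative activity, with a stated time of 72 h; a higher number here means that more compound is needed for the effect, a lower number that less compound is needed. Compound 1 `COc1ccc(-c2c(Cl)c(=O)c3c(OC)cc(OC)cc3n2S(=O)(=O)c2ccc(OC)cc2)cc1` has no result reported in this assay: "not determined" (no result reported). Compound 2 `COC(=O)c1cc(=O)c2cc(N)ccc2[nH]1` gives only a limit of the assay, > 33700 nM, and not a number. Compound 3 `COc1ccc(-c2cc(=O)c3c(OC)cc(OC)cc3n2S(=O)(=O)c2cccc([N+](=O)[O-])c2)cc1` likewise returns only a limit, > 39600 nM, in this assay. Going by the values given here, compound 3 thus stands at the limit described by the limit of > 39600 nM in this assay, at which 1 of the 3 values shown sits; compound 2 sits at the limit described by the limit of > 33700 nM in this assay, at which 1 of the 3 values shown sits; no compound in this set has a single number in this assay, and no step between measured compounds can be drawn.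

Compound 4 `COc1ccc(-c2cc(=O)c3c(OC)cc(OC)cc3n2S(=O)(=O)c2ccc(C)cc2)cc1` differs from compound 3 in a single place: 4-methylphenyl in place of 3-nitrophenyl on a sulfonyl sulfur. Among the compounds with values here, no measured step within this set bears on such a change, so there is no basis for expecting a shift beyond the scatter in either direction. The expected step, a step that the limit leaves unreadable from compound 3 to compound 4, is therefore essentially none. Compound 4 is estimated to give about 40000 nM in this assay, in a range from 10000 nM to 120000 nM, most likely again reported only as a limit.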

Compound 4, half-maximal effective concentration: > 44800 nM
Compound 4 gave a limit, no number; the forecaster's own chance of this, stated with the estimate: 70%; at least 1.1-fold (0.04 log units) between middle value and limit.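

In this assay compound 3 and compound 4 each return only a limit and not a number, and no step can be read between them. The compounds shown leave open whether 4-methylphenyl in place of 3-nitrophenyl on a sulfonyl sulfur changes the result in this assay at all.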